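Swapping Benzyl for Acetyl at the Limit of the Assay

The source may hold more compounds than are shown below. What is called first, only, known or untested is meant among the compounds shown, and "the series" means these compounds.

In a functional assay on HT-29 cells (Homo sapiens) for cytotoxicity (on this read-out lower numbers stand for stronger inhibition and higher numbers for weaker inhibition), compound 1 `CC(=O)Nc1[nH]nc2nnc(-c3ccccc3)c(-c3ccccc3)c12` gives > 100000 nM, which is a limit and not a number, and it carries an acetyl group. Compound 2 `Nc1nn(Cc2ccccc2)c2nnc(-c3ccccc3)c(-c3ccccc3)c12` gives > 100000 nM, again a limit. Compound 2 thus stands at the limit of > 100000 nM in this assay, at which 2 of the 2 values shown sit. Compound 3 `CC(=O)n1nc(N)c2c(-c3ccccc3)c(-c3ccccc3)nnc21` is still unmeasured. It differs from compound 2 by one change, (acetyl in place of benzyl on an aromatic nitrogen), with acetyl in place of benzyl on an aromatic nitrogen. Among the measured compounds shown here, no measured pair shows what this swap does. Since compound 1 holds an acetyl group and still gives > 100000 nM, no measurable gain is expected. The expected move, a number no higher from compound 2 to compound 3 (the limit leaves the size open), is estimated to stay within the usual scatter, with no clear direction. Compound 3 is expected at 100000 nM, with an estimated range from 30000 nM to 120000 nM, and it may well report only a limit.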

Compound 3, half-maximal inhibitory concentration: > 100000 nM
Compound 3: only a limit was reported (the forecaster's own chance of this, stated with the estimate: 80%); the middle value sits exactly at the limit.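

Compound 2 and compound 3 both report only a limit in this assay, and no step can be read between them for acetyl in place of benzyl. The compounds shown leave open how any change to the shared core would shift the read-out, as all of them stop at the same point: the limit of > 100000 nM in this assay, at which 3 of the 3 values shown sit.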